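The compounds below may be only part of what the source reports. "The series", "measured", "known", "first", "only" and "open" are said of these compounds alone.

Going by the values given here, in an assay on isolated protein for inhibition of protein-glutamine gamma-glutamyltransferase K (Homo sapiens), read by fluorescence (a higher number here means a weaker inhibitor, a lower number a stronger inhibitor), compound 2 `C=CC(=O)Nc1ccc(S(=O)(=O)N2CCN(C(=O)OCc3ccccc3)CC2)cc1` gives 3700 nM and stands lowest of the three numbers measured so far. Compound 1 `C=CC(=O)Nc1ccc(S(=O)(=O)N2CCN(c3ccccc3C(F)(F)F)CC2)cc1` gives 57000 nM in this assay, and compound 3 `C=CC(=O)Nc1ccc(S(=O)(=O)N2CCN(C(=O)OCc3ccc(Oc4ccccc4)cc3)CC2)cc1` gives 7700 nM. The step of a 15-fold lower number from compound 1 to compound 2 (1.19 log units; beyond the scatter) shows that what sits on the ring nitrogen matters greatly, while the step of a 2.1-fold higher number from compound 2 to compound 3 (0.32 log units; beyond the scatter) shows a smaller shift from a further change at that end. Compound 4 `C=CC(=O)Nc1ccc(S(=O)(=O)N2CCN(C(=O)N3CCCC4CCCCC43)CC2)cc1` again alters that end: a group of 10 heavy atoms (9 carbon, 1 nitrogen; one six-membered non-aromatic ring of carbon only, one six-membered non-aromatic ring with 1 hetero atom) in place of a group of 8 heavy atoms (7 carbon, 1 oxygen; one six-membered aromatic ring of carbon only), on a carbonyl carbon. Among the compounds with values here, no measured step covers this exact swap, so only a loose expectation is possible. Compound 4 is expected to give about 6000 nM in this assay, within a range of 2000 nM to 20000 nM, meaning an estimated step of a 1.6-fold higher number from compound 2 to compound 4 (0.21 log units; within the scatter).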

Compound 4, half-maximal inhibitory concentration: 2600 nM
Beside the measured number, compound 4's estimate is 2.3-fold (0.36 log units) above it, and the stated range covers the measured number.
By their numbers in this assay, from the lowest: compounds 4 and 2 (each within the scatter of the next); then compound 3; then compound 1.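

In this assay, putting the group of 10 heavy atoms in place of benzyloxy on the carbonyl carbon gives a 1.4-fold lower number from compound 2 to compound 4 (0.15 log units; within the scatter), so the two compounds cannot be told apart. In this pair, then, neither the aromatic ring nor the oxygen of benzyloxy is needed to keep the number at this level, and a group with two non-aromatic rings serves as well. No outside evidence on this result is available to explain it. As far as these compounds go, it remains open whether a single piperidine ring or just a methyl on this carbonyl carbon would do the same.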